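Swapping a Ring Amine for a Branched Chain Amine

The source may report more compounds than this note shows. Statements on the series, on what has been measured and on what is new or still open speak of the compounds shown alone.

Measured compounds in an in vitro assay on 293-EBNA cells for binding affinity to corticotropin-releasing factor receptor 1 (Homo sapiens); a higher number here means a weaker inhibitor, a lower number a stronger inhibitor:
compound 1 `Cc1nc(N2CCCCC2)c2nnn(-c3ccc(C(C)C)cc3Br)c2n1` gives 46 nM
compound 2 `COCCNc1nc(C)nc2c1nnn2-c1c(C)cc(C)cc1C` gives 1200 nM
compound 3 `CCCC(CCC)Nc1nc(C)nc2c1nnn2-c1c(C)cc(C)cc1C` gives 4 nM

Compound 1 stands second highest of the three numbers: compound 3 lies clearly lower, compound 2 clearly higher. Compound 4 `CCCCC(CC)Nc1nc(C)nc2c1nnn2-c1ccc(C(C)C)cc1Br` differs from compound 1 in one place: (1-ethylpentyl)amino in place of piperidin-1-yl on an aromatic carbon. Within the data shown here, the only measured step, a 300-fold lower number from compound 2 to compound 3 (2.48 log units; beyond the scatter), concerns a branched chain on such a nitrogen and is large; compound 3, which carries a similar branched chain, gives the lowest number in this assay . Among the measured compounds shown here, no measured step covers the loss of the piperidin-1-yl ring itself, so that part is uncertain. A lower number is expected for compound 4, with a step of about a 5.8-fold lower number from compound 1 to compound 4 (0.76 log units; beyond the scatter). Compound 4 is estimated at 8 nM, within 2 nM to 30 nM.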

Compound 4, inhibition constant: 3.1 nM
For compound 4 the middle estimate is 2.6-fold (0.41 log units) above the measured one; measured number inside the range.
By their numbers in this assay, from the lowest: compounds 4 and 3 (each within the scatter of the next); then compound 1; then compound 2.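

In this assay, the step from a ring to an open chain on this aromatic carbon is large, with (1-ethylpentyl)amino in place of piperidin-1-yl giving a 15-fold lower number from compound 1 to compound 4 (1.17 log units; beyond the scatter). The earlier step changed one open chain for another, whereas this one shows that the piperidin-1-yl ring can be replaced with a lower number as the result. Nothing at hand explains the drop.

This change removes the ring and adds a hydrogen-bond donor together, and the compounds shown do not separate the two. An open-chain diethylamino group, which has no amine hydrogen, would help tell them apart.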